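This account rests on a few compounds, and the source may have more. Where it says the series, first, only, none or still open, it means among the compounds named here.

Measured so far:
compound 1 `O=C1/C(=C/c2coc3ccccc3c2=O)N=C(c2ccccc2)N1c1ccc(S(=O)(=O)Nc2nccs2)cc1` — 88400 nM
compound 2 `NS(=O)(=O)c1ccc(NC2=NC(=O)/C(=C\c3coc4ccccc4c3=O)S2)cc1` — 2230 nM
compound 3 `CCOC1Oc2ccccc2C(=O)/C1=C/Nc1ccc(S(N)(=O)=O)cc1` — 33400 nM

In a functional assay on A549 cells (Homo sapiens) for cytotoxicity, read by sulforhodamine B assay, with a stated time of 72 h (a lower number here means a stronger inhibitor, a higher number a weaker inhibitor), compound 1 gives 88400 nM, the highest of the three numbers. The nearest is compound 3 at 33400 nM, a gap already beyond the scatter; the furthest is compound 2 at 2230 nM. Compound 2 and compound 3 each differ from compound 1 in several places at once, so no single change can be read off from them.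

Compound 4 `O=C1/C(=C/c2coc3ccccc3c2=O)N=C(c2ccccc2)N1c1ccc(S(=O)(=O)Nc2ccccn2)cc1` is the unmeasured one. It differs from compound 1 in one place: pyridin-2-yl in place of 1,3-thiazol-2-yl on a sulfonamide nitrogen. The rest of the molecule is kept. Within the data shown here, no measured pair shows this kind of exchange, so there is no step to lean on; the only anchor is the value of compound 1. An exchange of one aromatic ring for another at the end of the sulfonamide is not expected to move the number beyond the usual scatter. The step expected here, a 1.1-fold lower number from compound 1 to compound 4 (0.04 log units; within the scatter), is small and without a set direction. For compound 4 the estimate is 80000 nM, with a range from 30000 nM to 200000 nM; given how high compound 1 already sits, a result reported only as a limit is possible.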

Compound 4, half-maximal inhibitory concentration: > 100000 nM
Compound 4: only a limit was reported; the forecaster's own chance of this, stated with the estimate: 20%; middle value at least 1.2-fold (0.09 log units) from the limit.
By their numbers in this assay, from the lowest: compound 2; then compound 3; then compound 1. At a limit, above all of these: compound 4.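

Notes on the sulfonamide nitrogen: in this assay compound 4 gives > 100000 nM, which is a limit and not a number. Pyridin-2-yl in place of 1,3-thiazol-2-yl on a sulfonamide nitrogen gives the first step in the series that changes one place only, an at least 1.1-fold higher number from compound 1 to compound 4 (0.05 log units; that floor lies within the scatter), so this exchange shows no gain in potency, while the real size of the step stays unknown. Only a floor can be read for this step, and the top of the assay's range sets it: the limit of > 100000 nM in this assay, at which 1 of the 4 values shown sits.

Open, as far as these compounds go, is whether a carboxylic acid or a longer alkyl chain on this nitrogen, with the rest of compound 1 kept, would give a number inside the range. Among these compounds, also open is how far the group on this nitrogen matters at all, since this one step is the only evidence at this position.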